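From Heptyl to Fluoro: Estimating Compound 4

The source may hold more compounds than are shown below. What is called first, only, known or untested is meant among the compounds shown, and "the series" means these compounds.

Three measured compounds share one core and differ only in the chain on one aromatic carbon. Compound 1 `CCCc1ccc(NC(=O)N[C@@H](C)c2ccccc2)cc1` gives 73% in an ADME assay on the whole organism with Oryza sativa as the target, tested at 10 uM; a lower number here means a stronger effect, a higher number a weaker effect of the compound at the concentration tested. Compound 2 `CCCCCCc1ccc(NC(=O)N[C@@H](C)c2ccccc2)cc1` gives 99%, and compound 3 `CCCCCCCc1ccc(NC(=O)N[C@@H](C)c2ccccc2)cc1` gives 99%. Compound 3 is thus level with compound 2, the two together holding the highest number of the three, and it sits well above compound 1: a number 26 percentage points higher from compound 1 to compound 3 (beyond the scatter).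

Compound 4 `C[C@H](NC(=O)Nc1ccc(F)cc1)c1ccccc1` is not yet measured. Its change from compound 3: fluoro in place of heptyl on an aromatic carbon. The measured steps that bear on this are those that lengthen the chain, a number 26 percentage points higher from compound 1 to compound 2 (beyond the scatter) and a number 26 percentage points higher from compound 1 to compound 3 (beyond the scatter), while no change at the digits printed from compound 2 to compound 3 (within the scatter). Here the heptyl leaves and a single fluorine enters, which runs against those steps and goes further than any of them. The expected step is therefore a fall beyond the scatter, a number 44 percentage points lower from compound 3 to compound 4 (beyond the scatter). Compound 4 is expected to give 55%, between 30% and 85%.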

Compound 4, a percentage reported as activity, at one concentration (the size of the read-out at that concentration, not a potency): 85%
Compound 4: middle estimate off by 30 percentage points, on the low side, within the range that was stated.
By their numbers in this assay, from the lowest: compound 1; then compound 4; then compounds 2 and 3 (each within the scatter of the next).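

In this assay the fluoro group does not continue the trend seen with the chains, since replacing heptyl with fluoro gives a number 14 percentage points lower from compound 3 to compound 4 (beyond the scatter) and replacing hexyl with fluoro gives a number 14 percentage points lower from compound 2 to compound 4 (beyond the scatter), while replacing propyl with fluoro gives a number 12 percentage points higher from compound 1 to compound 4 (beyond the scatter) and so moves the number the other way. The number at this aromatic carbon therefore does not simply follow the count of heavy atoms in the group, as fluoro, with the fewest, falls short of hexyl and heptyl but exceeds propyl. No measurement here accounts for this placing of fluoro.

Open, from the compounds shown here alone, is where the plain hydrogen, a methyl or an ethyl would fall at this position. So is whether chloro, a hydroxyl or an amine would behave like fluoro.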